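Methyl on the triazole-bound phenyl: compound 3 to compound 4

The compounds below may be only part of what the source reports. "The series", "measured", "known", "first", "only" and "open" are said of these compounds alone.

Measured compounds, with their results in a functional assay on OVCAR-3 cells (Homo sapiens) for antiproliferative activity, read by MTT assay, with a stated time of 24 h; a higher number here means a weaker inhibitor, a lower number a stronger inhibitor:
compound 1, `Cc1cccc(-n2cc(-c3ccccc3NS(=O)(=O)c3c[nH]c(=O)[nH]c3=O)nn2)c1`, gives 3150 nM
compound 2, `O=c1[nH]cc(S(=O)(=O)Nc2ccccc2-c2cn(-c3ccccc3F)nn2)c(=O)[nH]1`, gives 15300 nM
compound 3, `O=c1[nH]cc(S(=O)(=O)Nc2cccc(-c3cn(-c4ccccc4)nn3)c2)c(=O)[nH]1`, gives > 20000 nM

The reading of compound 3 is a limit of the assay and not a number, as noted at the limit of > 20000 nM in this assay, at which 1 of the 3 values shown sits. Compound 3 therefore stands at the far end of the range seen here, with only compound 1 and compound 2 giving numbers.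

Compound 4, `Cc1ccc(-n2cc(-c3cccc(NS(=O)(=O)c4c[nH]c(=O)[nH]c4=O)c3)nn2)cc1`, differs from compound 3 by methyl in place of hydrogen on an aromatic carbon, so that the same difference, cut one bond further out, reads phenyl to 4-methylphenyl.

Going by the values given here, one measured step bears on the aryl attached to the triazole nitrogen: a 4.9-fold higher number from compound 1 to compound 2 (0.69 log units; beyond the scatter). That step exchanges one substituted phenyl for another and is modest. Among the compounds with values here, no measured step changes hydrogen for methyl on a bare phenyl, and none starts from a limit.

Given that compound 3 gives only a limit, the step of an at least 1.1-fold lower number from compound 3 to compound 4 (0.04 log units; that floor lies within the scatter) is expected to be small, with a fair chance that compound 4 again returns a limit. Compound 4 is estimated at 18000 nM, between 7000 nM and 45000 nM.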

Compound 4, half-maximal inhibitory concentration: 3540 nM
Beside the measured number, compound 4's estimate is 5.1-fold (0.71 log units) above it; measured number below the stated range.
By their numbers in this assay, from the lowest: compounds 1 and 4 (each within the scatter of the next); then compound 2. At a limit, above all of these: compound 3.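

In this assay, one methyl on an aromatic carbon, para to a large group, gives an at least 5.6-fold lower number from compound 3 to compound 4 (0.75 log units; beyond the scatter), so this place on the phenyl bound to the triazole nitrogen is not indifferent to substitution. Going by these compounds alone, the only earlier step, a 4.9-fold higher number from compound 1 to compound 2 (0.69 log units; beyond the scatter), exchanged one substituted phenyl for another, whereas this step starts from the bare phenyl and shows that adding a single methyl there is enough to turn a limit into a measured number. As far as these compounds go, the full size of the step stays unknown, as the reading of compound 3 is a limit of the assay and not a number: the limit of > 20000 nM in this assay, at which 1 of the 4 values shown sits.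

Whether this effect is specific to methyl remains open, as the compounds shown do not include an ethyl or longer chain, a chlorine, a methoxy group, an amine or a carboxylic acid at this place on the core of compound 4. Also open is whether a methyl placed elsewhere on the same phenyl of that core would give a comparable step, since the compounds shown hold only this one change from compound 3.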